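Lengthening the Amine Chain on an Inactive Acid

The compounds below may be only part of what the source reports. "The series", "measured", "known", "first", "only" and "open" are said of these compounds alone.

Compound 1, `N#CCCCc1c[nH]c2ccc(C(=O)O)cc12`, gives "not active" (no number reported) in an assay on isolated protein for inhibition of Myeloperoxidase (Homo sapiens), read by ELISA, with a stated time of 5 min; on this read-out higher numbers stand for weaker inhibition and lower numbers for stronger inhibition.
Compound 2, `NCCCc1c[nH]c2ccc(C(=O)O)cc12`, gives "not active" (no number reported) in this assay.
Compound 3, `N#CSCCCc1c[nH]c2ccc(F)cc12`, gives 23 nM in this assay.
Compound 4, `NCCCCc1c[nH]c2ccc(C(=O)O)cc12`, has not yet been measured in this assay.

Compound 2 stands without a single number: the assay reports it only as not active, and compound 1, the other carboxylic acid in this set, is reported the same way. Only compound 3, which carries fluorine in place of the carboxylic acid, has a number, and it is a strong one.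

Compound 4 is reached from compound 2 by one change: aminomethyl in place of amino on a saturated chain carbon, three bonds along the chain from an aromatic carbon. The chain grows by one carbon while the amine stays at its end and the carboxylic acid on the core stays in place. Both acids measured so far are inactive, and nothing in the set shows that chain length alone rescues activity in this assay. The expected step from compound 2 to compound 4 is therefore none beyond the scatter: compound 4 is expected to stay inactive, most likely reported again without a number.

If a number were returned, compound 4 is estimated at 30000 nM, with a range from 5000 nM to 200000 nM.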

Compound 4, half-maximal inhibitory concentration: "not active" (no number reported)
For compound 4 the study gives words and no number; no gap can be computed for the estimate.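

In this assay, among these compounds, compound 2 gives "not active" (no number reported) and compound 4 gives "not active" (no number reported) as well, so no step between the two can be read. The compounds shown leave open whether any chain length gives activity while the carboxylic acid stays on the core. No measurement at hand accounts for this result.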